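Swapping the pyrazole side group for a pyrimidine

The compounds below may be only part of what the source reports. "The series", "measured", "known", "first", "only" and "open" are said of these compounds alone.

Within the data shown here, compound 2 `COc1ccc(CNC(=O)c2cccc(C(C)Oc3ccnc(Nc4cnn(C5CCN(C)CC5)c4)c3)c2)cc1OC` has the lower of the two numbers measured so far in a functional assay on HCC78 cells (Homo sapiens) for antiproliferative activity, read by MTT assay, with a stated time of 48 h (a higher number here means a weaker inhibitor, a lower number a stronger inhibitor), where compound 2 gives 9000 nM. Among the measured compounds shown here, its only measured neighbour is compound 1 `COc1ccc(CNC(=O)c2cccc(C(C)Oc3ccnc(Nc4cnn(C)c4)c3)c2)cc1OC`, which in this assay gives 76600 nM; the step of an 8.5-fold lower number from compound 1 to compound 2 (0.93 log units; beyond the scatter) shows how much the 1-methylpiperidin-4-yl group helped. Compound 3 `COc1ccc(CNC(=O)c2cccc(C(C)Oc3ccnc(Nc4ncccn4)c3)c2)cc1OC` differs from compound 2 as follows: pyrimidin-2-yl in place of 1-(1-methylpiperidin-4-yl)-1H-pyrazol-4-yl on a nitrogen on an aromatic ring. For the measured compounds named here, no measured step covers exchanging the pyrazole ring itself, so the expectation rests on compound 1 and compound 2 alone: removing the 1-methylpiperidin-4-yl group, as in the step of an 8.5-fold lower number from compound 1 to compound 2 (0.93 log units; beyond the scatter) read backwards, is expected to push the number up. For compound 3 a step of a 5.6-fold higher number from compound 2 to compound 3 (0.74 log units; beyond the scatter) in this assay is therefore expected, giving a weaker inhibitor. The estimate for compound 3 is 50000 nM, within a range from 10000 nM to 200000 nM.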

Compound 3, half-maximal inhibitory concentration: > 100000 nM
Compound 3: no number, only a limit; the forecaster's own chance of this, stated with the estimate: 20%; at least 2.0-fold (0.30 log units) between middle value and limit.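

Compound 3 gives no number in this assay, only a limit of the assay: the limit of > 100000 nM in this assay, at which 1 of the 3 values shown sits.

Even so, replacing the 1-(1-methylpiperidin-4-yl)-1H-pyrazol-4-yl group with pyrimidin-2-yl gives an at least 11-fold higher number from compound 2 to compound 3 (1.04 log units; beyond the scatter), so this nitrogen on an aromatic ring tolerates a full exchange of its group far less well than the earlier compounds could show. Against the smaller 1-methyl-1H-pyrazol-4-yl group, the same exchange gives an at least 1.3-fold higher number from compound 1 to compound 3 (0.11 log units; that floor lies within the scatter), so compound 1 and compound 3 cannot be put in order.

The compounds shown leave open whether the loss follows from the new ring or from the missing 1-methylpiperidin-4-yl group, a question that a pyrimidin-2-yl ring carrying that group could settle. Also open, from the compounds shown here alone, is whether an open dimethylaminoethyl chain could replace the 1-methylpiperidin-4-yl group.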